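This account rests on a few compounds, and the source may have more. Where it says the series, first, only, none or still open, it means among the compounds named here.

Among the compounds with values here, compound 3 `COc1cccc(NC(=O)Nc2ccc(Oc3ncnc4[nH]ncc34)cc2)c1` gives 82000 nM in an assay on isolated protein for inhibition of vascular endothelial growth factor receptor 2 (Danio rerio), read by fluorescence and microscopy, with a stated time of 33 h (a lower number here means a stronger inhibitor, a higher number a weaker inhibitor), the only number in the set. Compound 1 `O=C(Nc1ccc(Br)cc1)Nc1ccc(Nc2ncnc3[nH]ncc23)cc1` sits at the limit > 100000 nM in this assay. Compound 2 `O=C(Nc1ccc(Nc2ncnc3[nH]ncc23)cc1)Nc1ccc(C(F)(F)F)cc1` likewise sits at the limit > 100000 nM in this assay. The step that the two limits leave unreadable from compound 1 to compound 2 therefore remains unreadable, and the limit of > 100000 nM in this assay, at which 2 of the 3 values shown sit, is all that the measured steps offer. Compound 4 `Cc1cccc(NC(=O)Nc2ccc(Oc3ncnc4[nH]ncc34)cc2)c1C` differs from compound 3 by 2,3-dimethylphenyl in place of 3-methoxyphenyl on an amide-type nitrogen. Within the data shown here, no measured step touches this change, so nothing beyond the scatter is expected in this assay in either direction. The expected step is a 1.1-fold higher number from compound 3 to compound 4 (0.04 log units; within the scatter), with a wide spread. Compound 4 is estimated at 90000 nM, ranging from 30000 nM to 300000 nM.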

Compound 4, half-maximal inhibitory concentration: 98800 nM
Compound 4: middle estimate off by 1.1-fold (0.04 log units), on the low side, and the stated range covers the measured number.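

In this assay, the change to 2,3-dimethylphenyl in place of 3-methoxyphenyl on an amide-type nitrogen gives a 1.2-fold higher number from compound 3 to compound 4 (0.08 log units; within the scatter). Within the data shown here, this is the first readable step, and it lies within the scatter. At this position, a group with 1 hydrogen-bond acceptor and one with 0 are not told apart by this measurement.

Compounds 1 and 2 offer no number to compare with this pair, as their values are limits of the assay: the limit of > 100000 nM in this assay, at which 2 of the 4 values shown sit.

Going by these compounds, whether an amine or a carboxylic acid in place of this aryl group on the amide-type nitrogen would give a step beyond the scatter remains open.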